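The compounds below may be only part of what the source reports. "The series", "measured", "known", "first", "only" and "open" are said of these compounds alone.

Measured compounds and their values:
- Compound 1 `COc1cc(/C=C/C(=O)/C=C/c2ccco2)ccc1OCc1cn(CCCOc2cc(=O)oc3ccccc23)nn1`: 57%
- Compound 2 `COc1ccccc1/C=C/C(=O)/C=C/c1ccc(OCc2cn(CCCCOc3cc(=O)oc4ccccc34)nn2)c(OC)c1`: 40%
- Compound 3 `COc1ccccc1/C=C/C(=O)/C=C/c1ccc(OCc2cn(CCCCCOc3cc(=O)oc4ccccc34)nn2)c(OC)c1`: 37%

These three compounds were tested in a functional assay on THP-1 cells (Homo sapiens) for inhibition, read by sulforhodamine B assay, with a stated time of 48 h, tested at 50 uM; a higher number here means more inhibition of growth at the concentration tested, a lower number less inhibition of growth. Compound 1 stands highest at 57%, and its gaps to the other two lie beyond the usual scatter. Compound 2 and compound 3 lie within the scatter of each other.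

The next compound to consider is compound 4 `COc1ccc(/C=C/C(=O)/C=C/c2ccc(OCc3cn(CCCOc4cc(=O)oc5ccccc45)nn3)c(OC)c2)cc1OC`, which differs from compound 1 in one place: 3,4-dimethoxyphenyl in place of furan-2-yl on a double-bonded chain carbon bound to a double-bonded chain carbon. In plain terms, 3,4-dimethoxyphenyl stands in place of furan-2-yl on a double-bonded chain carbon bound to a double-bonded chain carbon, so this end of the molecule becomes larger.

Among the measured compounds shown here, no measured pair shows this change on its own, which makes any forecast uncertain. Compound 2 at 40% and compound 3 at 37% also lack the furan-2-yl group, and both sit lower than compound 1. However, they differ from compound 1 elsewhere too, so they offer only a weak hint of a downward direction.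

The expected step of a number 11 percentage points lower from compound 1 to compound 4 (beyond the scatter) is a modest fall, close to the size of the scatter. Compound 4 is expected to give 46%, with an estimated range of 30% to 62%.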

Compound 4, percent growth inhibition at one concentration: 73%
Estimate against measurement, compound 4: 27 percentage points below, and the stated range ends below it.
By their numbers in this assay, from the lowest: compounds 3 and 2 (each within the scatter of the next); then compound 1; then compound 4.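

In this assay, among the compounds shown here, replacing furan-2-yl with 3,4-dimethoxyphenyl gives a number 16 percentage points higher from compound 1 to compound 4 (beyond the scatter), and this is the first effect of a change in one place that these compounds can show. The earlier compounds shown here differed from one another in more than one place, so they could not reveal that this end of the molecule tolerates a larger group, with 10 heavy atoms in place of 5, and that growth inhibition rises with this swap. Nothing available here explains why the number rises, so the step records only what happened, not its cause.

This single pair cannot separate the change of ring from the addition of the two methoxy groups, and a plain phenyl group or a 4-methoxyphenyl group at the same place would help to tell those apart. It also leaves open whether this end accepts a quite different kind of group, such as an amine or a carboxylic acid on the ring, and whether the gain holds in other cell lines.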